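This account rests on a few compounds, and the source may have more. Where it says the series, first, only, none or still open, it means among the compounds named here.

Working notes on the series, all read in a functional assay on HL-60 cells (Homo sapiens) for cytotoxicity, read by WST assay, with a stated time of 48 h; on this read-out lower numbers stand for stronger inhibition and higher numbers for weaker inhibition. Within the data shown here, compound 3 (`CC[C@H](C(C)C)C(c1ccc(O)c(OC)c1)c1ccc(O)c(OC)c1`) gives 16000 nM, the lowest number so far. Compound 2 (`COC[C@@H](C)[C@@H](C)C(c1ccc(O)c(OC)c1)c1ccc(O)c(OC)c1`) gives 85000 nM. Compound 1 (`COc1cc(C(c2ccc(O)c(OC)c2)[C@@H](C)[C@@H](C)CO)ccc1O`) gives > 100000 nM, which is a limit of the assay and not a number.

Compound 4 (`COc1cc(C(c2ccc(O)c(OC)c2)[C@@H](CF)C(C)C)ccc1O`) is still to be measured. Its change from the nearest measured compound is 1-(fluoromethyl)-2-methylpropyl in place of 1-isopropylpropyl on a saturated chain carbon bound to two aromatic carbons: 1-(fluoromethyl)-2-methylpropyl in place of 1-isopropylpropyl, on a saturated chain carbon bound to two aromatic carbons.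

Among the measured compounds shown here, two measured steps bear on this place. The modest 5.3-fold lower number from compound 2 to compound 3 (0.73 log units; beyond the scatter) is beyond the scatter, and an at least 6.2-fold lower number from compound 1 to compound 3 (0.79 log units; beyond the scatter) is also beyond it, though only as a floor. Both end at the all-carbon chain of compound 3, while the chains they start from carry oxygen. For the measured compounds named here, the change to compound 4 puts a heteroatom back into the chain, but no measured compound carries fluorine, so these steps give only a loose direction. A small move towards a higher number is expected, smaller than a 5.3-fold lower number from compound 2 to compound 3 (0.73 log units; beyond the scatter) and possibly within the scatter. The expected step is a 1.6-fold higher number from compound 3 to compound 4 (0.19 log units; within the scatter). For compound 4 the estimate is 25000 nM, with an expected range of 8000 nM to 70000 nM.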

Compound 4, half-maximal inhibitory concentration: 39000 nM
Beside the measured number, compound 4's estimate is 1.6-fold (0.19 log units) below it, within the range that was stated.
By their numbers in this assay, from the lowest: compound 3; then compound 4; then compound 2. At a limit, above all of these: compound 1.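

In this assay, the step of a 2.4-fold higher number from compound 3 to compound 4 (0.39 log units; beyond the scatter) shows that this place responds to a change that leaves the count of 6 heavy atoms intact, with 1 fluorine taking the place of 1 carbon in the chain on the saturated chain carbon bound to two aromatic carbons. The fluorine-bearing chain still keeps part of the gain seen with the all-carbon chain, as the step of a 2.2-fold lower number from compound 2 to compound 4 (0.34 log units; beyond the scatter) shows, so among the three chains with measured numbers, 1-(fluoromethyl)-2-methylpropyl falls between 1-isopropylpropyl and 2-(methoxymethyl)-1-methylpropyl. Against compound 1 only a floor can be read, an at least 2.5-fold lower number from compound 1 to compound 4 (0.40 log units; beyond the scatter), and the value of compound 1 is a limit of the assay and not a number: the limit of > 100000 nM in this assay, at which 1 of the 4 values shown sits.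

From the compounds shown here alone, with a single fluorine-bearing chain in the set, it remains open whether the rise from compound 3 belongs to fluorine itself or to the shape of the new chain. Going by these compounds, a difluoromethyl, trifluoromethyl, chloromethyl or aminomethyl group, or a longer chain at this place, would be needed to separate the two, and the opposite configuration at the defined stereocentre also remains open.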